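Sugar to open-chain diol swap on the aromatic nitrogen

A few compounds are considered here, and "the series" means these few. Any claim that something is new, unique, unknown or untested is made for them only; others in the source may bear on it.

Three compounds share one core. Compound 1 `O=C1c2c[n+]([O-])c3ccccc3c2C(=O)c2c1c1ccccc1n2Cc1cn([C@@H]2C[C@H](O)[C@@H](CO)O2)nn1` gives 20 nM in a functional assay on A-375 cells (Homo sapiens) for cytotoxicity, read by MTT assay, with a stated time of 72 h; on this read-out higher numbers stand for weaker inhibition and lower numbers for stronger inhibition. Compound 2 `CN(C)CCCCCn1c2c(c3ccccc31)C(=O)c1c[n+]([O-])c3ccccc3c1C2=O` gives 560 nM. Compound 3 `O=C1c2c[n+]([O-])c3ccccc3c2C(=O)c2c1c1ccccc1n2Cc1cn([C@@H]2O[C@H](CO)[C@@H](O)[C@H](O)[C@H]2O)nn1` gives 230 nM, the second highest of the three numbers; compound 2 lies above it and compound 1 well below it. Compound 4 `O=C1c2c[n+]([O-])c3ccccc3c2C(=O)c2c1c1ccccc1n2Cc1cn(C[C@H](O)CO)nn1` carries 2,3-dihydroxypropyl in place of 3,4,5-trihydroxy-6-(hydroxymethyl)oxan-2-yl on an aromatic nitrogen. For the measured compounds named here, the only measured step that bears on this change is the exchange of one sugar for another, a 12-fold higher number from compound 1 to compound 3 (1.06 log units; beyond the scatter), which shows that the group on this nitrogen moves the read-out strongly; no measured step covers an open-chain group. With the smaller entering group, the expected outcome for compound 4 is a moderate step to a lower number a 2.9-fold lower number from compound 3 to compound 4 (0.46 log units; beyond the scatter). Compound 4 is estimated at 80 nM, range 20 nM to 350 nM.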

Compound 4, half-maximal inhibitory concentration: 350 nM
Compound 4: middle estimate off by 4.4-fold (0.64 log units), on the low side, within the range that was stated.
By their numbers in this assay, from the lowest: compound 1; then compounds 3, 4 and 2 (each within the scatter of the next, the first and the last beyond it).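

In this assay, replacing the six-membered sugar with the open-chain 2,3-dihydroxypropyl group does not separate the two compounds: a 1.5-fold higher number from compound 3 to compound 4 (0.18 log units; within the scatter). The same holds for the dimethylamino chain, a 1.6-fold lower number from compound 2 to compound 4 (0.20 log units; within the scatter), whereas an 18-fold higher number from compound 1 to compound 4 (1.24 log units; beyond the scatter) sets the 4-hydroxy-5-(hydroxymethyl)oxolan-2-yl group of compound 1 apart from the open-chain diol. What distinguishes that group remains unexplained, as no supporting data bear on it. A carboxylic acid or a longer chain ending in a primary amine on this aromatic nitrogen remains an open case.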